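Swapping the aryl group on a kinase binder

This account rests on a few compounds, and the source may have more. Where it says the series, first, only, none or still open, it means among the compounds named here.

For the measured compounds named here, compound 2 `CCCS(=O)(=O)Nc1ccc(F)c(C(=O)c2n[nH]c3ncc(-c4ccc(Cl)cc4Cl)cc23)c1F` is the weaker of the two compounds measured so far in an assay for binding affinity to dual specificity mitogen-activated protein kinase kinase 4 (Homo sapiens), read by KINOMEscan, tested at 100 nM; on this read-out higher numbers stand for a weaker effect at the one concentration tested and lower numbers for a stronger effect. In this assay compound 2 gives 22%, while compound 1 `CCCS(=O)(=O)Nc1ccc(F)c(C(=O)c2n[nH]c3ncc(-c4ccccc4OC)cc23)c1F` gives 1.9%. Going by the values given here, the only measured step so far, a number 20.1 percentage points higher from compound 1 to compound 2 (beyond the scatter), shows that exchanging the aryl group attached to the shared core moves the read-out by a modest but real amount.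

Compound 3 `CCCS(=O)(=O)Nc1ccc(F)c(C(=O)c2n[nH]c3ncc(-c4ccc(C(F)(F)F)cc4)cc23)c1F` differs from compound 2 in just that aryl group: 4-(trifluoromethyl)phenyl in place of 2,4-dichlorophenyl on an aromatic carbon. Among the compounds with values here, no measured step involves a 4-(trifluoromethyl)phenyl group, so the direction of this change cannot be read from the data. The step from compound 1 to compound 2 only shows that an aryl exchange at this position can shift the read-out by a modest amount, in either direction in principle. The expected step is therefore small and uncertain, a number 7 percentage points lower from compound 2 to compound 3 (within the scatter), with a wide spread. For compound 3 the estimate in this assay is 15%, within a range from 2% to 45%.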

Compound 3, a percentage reported as activity, at one concentration (the size of the read-out at that concentration, not a potency): 29%
For compound 3 the middle estimate is 14 percentage points below the measured one, within the range that was stated.
By their numbers in this assay, from the lowest: compound 1; then compounds 2 and 3 (each within the scatter of the next).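

In this assay, putting 4-(trifluoromethyl)phenyl in place of 2,4-dichlorophenyl gives a number 7 percentage points higher from compound 2 to compound 3 (within the scatter) and so does not separate these two aryl groups, even though they differ in their substituents and the entering group has more heavy atoms. Putting the same group in place of 2-methoxyphenyl gives a number 27.1 percentage points higher from compound 1 to compound 3 (beyond the scatter) and so repeats, with a second and differently substituted aryl group, the gap first seen with compound 2: among these three compounds, compound 1 stands apart, while compounds 2 and 3 read alike. No supporting data are available to explain why the 2-methoxyphenyl compound differs from the other two.

These three compounds leave open whether the gap belongs to the methoxy group itself or to the way the aryl ring is substituted, and a plain phenyl ring or a 4-methoxyphenyl group at this carbon would help to separate those two readings. From the compounds shown here alone, it also remains open how an aryl ring carrying an amine or a carboxylic acid would read here.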